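Trading a methoxyphenyl for a chlorophenyl on a bis-sulfonamide

This account rests on a few compounds, and the source may have more. Where it says the series, first, only, none or still open, it means among the compounds named here.

Of the compounds shown here, three built on one shared core have been measured in an assay for binding affinity to protein lin-28 homolog A (Mus musculus), with a stated time of 1 h; on this read-out higher numbers stand for weaker inhibition and lower numbers for stronger inhibition. Compound 1 `O=S(=O)(Nc1ccccc1NS(=O)(=O)c1ccc(F)cc1)c1ccc(F)cc1` gives 28300 nM. Compound 2 `O=S(=O)(Nc1ccccc1NS(=O)(=O)c1ccc(Cl)cc1)c1ccc(F)cc1` gives 27300 nM, and compound 3 `COc1ccc(S(=O)(=O)Nc2ccccc2NS(=O)(=O)c2ccc(F)cc2)cc1` gives 17200 nM. Compound 3 shows the lowest of the three numbers, but the two steps that end at it are only a 1.6-fold lower number from compound 2 to compound 3 (0.20 log units; within the scatter) and a 1.6-fold lower number from compound 1 to compound 3 (0.22 log units; within the scatter), so all three sit together and none can be called stronger than the others.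

Compound 4 `O=S(=O)(Nc1ccccc1NS(=O)(=O)c1cccc(Cl)c1)c1ccc(F)cc1` is not yet measured. The change from compound 3 is 3-chlorophenyl in place of 4-methoxyphenyl on a sulfonyl sulfur. Two measured steps speak to it. Read backwards, a 1.6-fold lower number from compound 2 to compound 3 (0.20 log units; within the scatter) shows what replacing a methoxy group by a chlorine did, although there the chlorine sat on a different carbon of the ring than in compound 4. The step of a 1.0-fold lower number from compound 1 to compound 2 (0.02 log units; within the scatter) shows that swapping one halogen for another left the number essentially unchanged. Nothing among these steps was beyond the scatter, so for this assay no step beyond the scatter is expected, with at most a slight drift toward higher numbers.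

Compound 4 is therefore expected to give 24000 nM, with a range from 11000 nM to 52000 nM. This estimate corresponds to an expected step of a 1.4-fold higher number from compound 3 to compound 4 (0.14 log units; within the scatter).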

Compound 4, half-maximal inhibitory concentration: 10800 nM
Beside the measured number, compound 4's estimate is 2.2-fold (0.35 log units) above it; measured number below the stated range.
By their numbers in this assay, from the lowest: compounds 4, 3, 2 and 1 (each within the scatter of the next, the first and the last beyond it).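

In this assay this position on the sulfonyl sulfur gives its first steps beyond the scatter: the step of a 2.5-fold lower number from compound 2 to compound 4 (0.40 log units; beyond the scatter) is modest, yet it exchanges only 4-chlorophenyl for 3-chlorophenyl, so where the chlorine sits on this ring can matter even when the halogen stays the same. The step of a 2.6-fold lower number from compound 1 to compound 4 (0.42 log units; beyond the scatter) is of similar size and also lies beyond the scatter, whereas the exchanges among 4-fluorophenyl, 4-chlorophenyl and 4-methoxyphenyl all stayed within it. Compound 3 goes against any clean split between the 3-chlorophenyl group and the other groups, since the step of a 1.6-fold lower number from compound 3 to compound 4 (0.20 log units; within the scatter) stays within the scatter, and nothing at hand explains these differences.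

Going by these compounds, it remains open whether the gain belongs to chlorine itself or would also appear with 3-fluorophenyl, 3-methoxyphenyl, or a phenyl ring carrying an amine or a carboxylic acid. On these data alone, it is also open how the number would respond to changes on the other sulfonyl sulfur, which carries a 4-fluorophenyl group in all four compounds.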